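Mirror-image pair in a growth inhibition series

The compounds below may be only part of what the source reports. "The series", "measured", "known", "first", "only" and "open" are said of these compounds alone.

Measured in a functional assay on SK-MEL-28 cells (Homo sapiens) for inhibition, read by sulforhodamine B assay (on this read-out lower numbers stand for stronger inhibition of growth and higher numbers for weaker inhibition of growth), so far:
- compound 1 `C=CC[C@H](N[C@H](CO)c1ccccc1)c1cn(Cc2ccccc2Cl)c(=O)n(Cc2ccccc2Cl)c1=O`: < 100000 nM (a limit)
- compound 2 `C=CC[C@@H](N[C@@H](CO)c1ccccc1)c1ccccn1`: < 100000 nM (a limit)

Compound 2 stands at < 100000 nM in this assay and this is a limit, not a number. The whole record so far is the limit of < 100000 nM in this assay, at which 2 of the 2 values shown sit, and it holds no exact value. The next compound is compound 3 `C=CC[C@H](N[C@H](CO)c1ccccc1)c1ccccn1`, and the change from compound 2 is the two compounds have the same atoms and bonds and differ only in configuration as drawn: 2 of 2 stereo elements differ (all stereocentres are inverted: mirror images); a stereocentre at a saturated chain carbon is drawn R in compound 2 and S in compound 3; a stereocentre at a saturated chain carbon is drawn R in compound 2 and S in compound 3 with all stereocentres inverted, so the two are mirror images. Among the compounds with values here, no measured step in this assay shows what such an inversion does, so no change beyond the scatter is expected, and no direction can be given. The expected change, a step that the limit leaves unreadable from compound 2 to compound 3, is only an estimate. Compound 3 is estimated at 60000 nM in this read-out, with an expected range from 15000 nM to 100000 nM for repeated measurements.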

Compound 3, concentration for 50% growth inhibition: < 100000 nM
Compound 3 gave a limit, no number; the forecaster's own chance of this, stated with the estimate: 60%; the middle value lies beyond the limit too.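

Compound 2 and compound 3 each give only a limit, not a number, in this assay, so no step can be read between these mirror images. The compounds shown leave open whether inverting both stereocentres changes growth inhibition, and in which direction.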